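A few compounds are considered here, and "the series" means these few. Any claim that something is new, unique, unknown or untested is made for them only; others in the source may bear on it.

Measured so far in an assay on RPMI-8226 cells for antagonist activity at P2X purinoceptor 7 (Homo sapiens), read by calcium flux; a lower number here means a stronger inhibitor, a higher number a weaker inhibitor:
- compound 1 `c1ccc(-c2nc3ccccc3n2CCCCN2CCN(C(c3ccccc3)c3ccccc3)CC2)cc1`: 1200 nM
- compound 2 `Cc1cccc2c1ccn2CCCCN1CCN(C(c2ccccc2)c2ccccc2)CC1`: 5300 nM

Compound 2 holds the higher of the two numbers; the gap down to compound 1 lies beyond the scatter, so compound 1 is the stronger inhibitor of the pair.

Compound 3 `N#Cc1ccc2c(ccn2CCCCN2CCN(C(c3ccccc3)c3ccccc3)CC2)c1` differs from compound 2 by a group of 11 heavy atoms (9 carbon, 2 nitrogen; one five-membered aromatic ring with 1 hetero atom, one six-membered aromatic ring of carbon only) in place of a group of 10 heavy atoms (9 carbon, 1 nitrogen; one five-membered aromatic ring with 1 hetero atom, one six-membered aromatic ring of carbon only), on a saturated chain carbon, four bonds along the chain from an amine nitrogen in a ring. Among the compounds with values here, no measured pair shows the effect of this exchange, so only a small step is expected, direction uncertain. Compound 3 is expected near 4000 nM, plausibly between 1500 nM and 12000 nM. The estimated step of a 1.3-fold lower number from compound 2 to compound 3 (0.12 log units; within the scatter) is expected to stay within the scatter.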

Compound 3, half-maximal inhibitory concentration: 3800 nM
The estimate for compound 3 lay 1.1-fold (0.02 log units) above the measured number; low and high end bracket the measured number.
By their numbers in this assay, from the lowest: compound 1; then compounds 3 and 2 (each within the scatter of the next).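

In this assay, bringing in 5-cyano-1H-indol-1-yl on the saturated chain carbon, four bonds along the chain from an amine nitrogen in a ring, gives a 1.4-fold lower number from compound 2 to compound 3 (0.14 log units; within the scatter) as its step. Within the data shown here, this is the first single-place exchange readable, and at this position a nitrile-bearing group and the group it replaces cannot be told apart. No measured data bear on this result.

Still open, going by these compounds, is whether a carboxylic acid or an amine in place of the nitrile would give a step beyond the scatter. On these data alone, whether a longer chain would do so at this position is equally open.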